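Methoxy to formyl on the pendant aryl ring

The source may hold more compounds than are shown below. What is called first, only, known or untested is meant among the compounds shown, and "the series" means these compounds.

Three compounds of the series have numbers in a functional assay on RPMI-8226 cells (Homo sapiens) for inhibition, read by sulforhodamine B assay, with a stated time of 48 h, tested at 10 uM; on this read-out higher numbers stand for more inhibition at the one concentration tested (going by the name of the read-out) and lower numbers for less inhibition. Compound 1 `Brc1cn2ccnc2c(-c2ccc3ncn(C4CCCCC4)c3c2)n1` gives 14.9% in this assay. Compound 2 `c1ccc(-c2cn3ccnc3c(-c3ccc4ncn(C5CCCCC5)c4c3)n2)cc1` gives 85.7%, and compound 3 `COc1ccc(-c2cn3ccnc3c(-c3ccc4ncn(C5CCCCC5)c4c3)n2)cc1` gives 95.6%. Compound 3 holds the highest of the three numbers, but compound 2 sits within the scatter of it, and only compound 1 lies beyond the scatter below it. The two large steps are a number 70.8 percentage points higher from compound 1 to compound 2 (beyond the scatter) and a number 80.7 percentage points higher from compound 1 to compound 3 (beyond the scatter), both replacing the bromo with an aryl ring. The small step is a number 9.9 percentage points higher from compound 2 to compound 3 (within the scatter), a methoxy added to the aryl ring, which stays within the scatter.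

Compound 4 `O=Cc1ccc(-c2cn3ccnc3c(-c3ccc4ncn(C5CCCCC5)c4c3)n2)cc1` has not been measured in this assay. It differs from compound 3 by formyl in place of methoxy on an aromatic carbon. For the measured compounds named here, the step that bears on this change is the one from compound 2 to compound 3: the methoxy itself moved the number only within the scatter, so the aryl ring, not its substituent, carries the large effect seen from compound 1. The formyl is therefore expected to leave compound 4 close to compound 3, with a step of a number 10.6 percentage points lower from compound 3 to compound 4 (beyond the scatter), not beyond the scatter. For compound 4 the expected value is 85%, within 62% to 98%.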

Compound 4, a percentage reported as inhibition, at one concentration (the size of the read-out at that concentration, not a potency): 82.5%
Beside the measured number, compound 4's estimate is 2.5 percentage points above it; measured number inside the range.
By their numbers in this assay, from the lowest: compound 1; then compounds 4, 2 and 3 (each within the scatter of the next, the first and the last beyond it).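

In this assay the position para to a large group on the pendant ring now shows that a swap between two substituents can reach beyond the scatter: formyl in place of methoxy gives a number 13.1 percentage points lower from compound 3 to compound 4 (beyond the scatter) as a modest step, which the earlier addition of methoxy to the bare ring did not show. The gap is only visible between the two substituents, since formyl in place of hydrogen gives a number 3.2 percentage points lower from compound 2 to compound 4 (within the scatter) and so compound 4 cannot be told apart from compound 2, just as compound 3 could not. The large gain over the bromo compound also holds with a third aryl ring, at a number 67.6 percentage points higher from compound 1 to compound 4 (beyond the scatter) for 4-formylphenyl in place of bromo, so on these compounds all three aryl rings stand far from compound 1 whichever para group they carry.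

On these data alone, whether an amine, a carboxylic acid or a longer chain at this position would stay with these three aryl compounds or fall towards compound 1 remains open. Nothing available explains why methoxy and formyl end up apart when neither separates from hydrogen.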